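Moving the bromine on a chalcone's aryl ring

The compounds below may be only part of what the source reports. "The series", "measured", "known", "first", "only" and "open" are said of these compounds alone.

Compound 1 `COc1ccc(/C=C/C(=O)c2cccc(-c3ccc(F)cc3)c2)cc1OC` — > 50000 nM
Compound 2 `O=C(/C=C/c1cccc(Br)c1)c1cccc(-c2cccc(F)c2)c1` — 11200 nM

In an assay on A549 cells for inhibition of transcription factor p65 (Homo sapiens), read by fluorescence, with a stated time of 2 h (a lower number here means a stronger inhibitor, a higher number a weaker inhibitor), compound 1 gives only a limit, > 50000 nM, not a number. For the measured compounds named here, compound 2 stands as the sole compound with a measured number; in this assay compound 2 gives 11200 nM. Compound 3 `O=C(/C=C/c1ccc(Br)cc1)c1cccc(-c2cccc(F)c2)c1` has the same atoms as compound 2, joined differently: 4-bromophenyl in place of 3-bromophenyl on a double-bonded chain carbon bound to a double-bonded chain carbon. Going by the values given here, no measured pair differs in a single place, so the size of such a step is unknown from these data. The step in this assay is expected to lie within the scatter, with no clear direction: a 1.0-fold lower number from compound 2 to compound 3 (0.01 log units; within the scatter). Compound 3 is estimated at 11000 nM, within 4000 nM to 35000 nM.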

Compound 3, half-maximal inhibitory concentration: > 50000 nM
Compound 3: a limit, no number (the forecaster's own chance of this, stated with the estimate: 15%); middle value at least 4.5-fold (0.65 log units) from the limit.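

In this assay, 4-bromophenyl in place of 3-bromophenyl on a double-bonded chain carbon bound to a double-bonded chain carbon gives an at least 4.4-fold higher number from compound 2 to compound 3 (0.64 log units; beyond the scatter). This position is therefore sensitive to where the bromine sits, even though the atoms stay the same. Compound 3 gives a limit, not a number, so the step is only a floor: the limit of > 50000 nM in this assay, at which 2 of the 3 values shown sit.

The compounds shown leave open whether the bromine itself is needed. A chlorine atom or an amine in its place could hold, lose or improve on the value of compound 2.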